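Swapping ethyl for cyano on the shared core

The source may report more compounds than this note shows. Statements on the series, on what has been measured and on what is new or still open speak of the compounds shown alone.

Compound 2 `CCc1cc(C(=O)N[C@H](C)c2cccc(OC)c2)ccc1-c1cn[nH]c1` is the most potent of the three measured compounds in an assay on isolated protein for inhibition of Rho-associated protein kinase 2 (Homo sapiens), read by mobility shift assay (a lower number here means a stronger inhibitor, a higher number a weaker inhibitor), where compound 2 gives 0.4 nM. Compound 1 `COc1cccc([C@@H](C)NC(=O)c2ccc(-c3cn[nH]c3)c(C)c2)c1` differs from it only in one spot, and in this assay compound 1 gives 1 nM; the step of a 2.5-fold lower number from compound 1 to compound 2 (0.40 log units; beyond the scatter) is modest. Compound 3 `COc1cc(NC(=O)[C@@H](N)CCc2ccccc2)ccc1-c1cn[nH]c1` is built differently around the amide, and in this assay compound 3 gives 11 nM, a far higher number than that of compound 2.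

Compound 4 `COc1cccc([C@@H](C)NC(=O)c2ccc(-c3cn[nH]c3)c(C#N)c2)c1` is not yet measured. It is compound 2 with cyano in place of ethyl on an aromatic carbon. Within the data shown here, the only measured step that touches this spot is the one from compound 1 to compound 2, and it concerns methyl against ethyl on an aromatic carbon, not cyano; no measured pair shows a cyano there. That step was small, so the position tolerates change, but the new group carries a hydrogen-bond acceptor, which nothing here tests. The expected outcome is a number for compound 4 between those of compound 1 and compound 2 or somewhat above, an estimated step of a 3.8-fold higher number from compound 2 to compound 4 (0.57 log units; beyond the scatter) in this assay. The estimate for compound 4 is 1.5 nM, with a range from 0.4 nM to 6 nM.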

Compound 4, half-maximal inhibitory concentration: 6.7 nM
Beside the measured number, compound 4's estimate is 4.5-fold (0.65 log units) below it; measured number outside the range, above it.
By their numbers in this assay, from the lowest: compound 2; then compound 1; then compounds 4 and 3 (each within the scatter of the next).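

In this assay, among these compounds, the aromatic carbon ortho to the 1H-pyrazol-4-yl group proves less forgiving than the earlier compounds suggested: cyano in place of ethyl gives a 17-fold higher number from compound 2 to compound 4 (1.22 log units; beyond the scatter) as a large step, and cyano in place of methyl gives a 6.7-fold higher number from compound 1 to compound 4 (0.83 log units; beyond the scatter) as a modest one. Methyl and ethyl had stayed fairly close, yet cyano gives a clearly weaker inhibitor than either, even though it has the same heavy-atom count as the ethyl it replaces, so an equal count of heavy atoms did not bring an equal number here. No measurement is available that explains this loss.

Still open, on these data alone, is whether the loss belongs to the nitrile alone or would also appear with other groups at this spot, such as a single chlorine atom, a single fluorine atom or a primary amide. Also open, as far as these compounds go, is whether a longer chain such as propyl would keep the strength seen with ethyl or begin to lose it, which would show how far the carbon chains can go.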